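Adding a Second Chloro Group: Expected Effect in Mice

The source may hold more compounds than are shown below. What is called first, only, known or untested is meant among the compounds shown, and "the series" means these compounds.

Compound 1 `OC1CCN(c2ccc(-c3ccccc3)nn2)CC1` is the simplest member of the group. In a functional assay on the whole organism with Mus musculus as the target, in the maximal electroshock model (a higher number here means that more compound is needed for the effect, a lower number that less compound is needed), compound 1 gives 86 mg/kg. Compound 2 `OC1CCN(c2ccc(-c3cccc(Cl)c3)nn2)CC1` differs from it by chloro in place of hydrogen on an aromatic carbon, and in this assay compound 2 gives 45 mg/kg, a step of a 1.9-fold lower number from compound 1 to compound 2 (0.28 log units; within the scatter). Compound 3 `CNC(=O)OC1CCN(c2ccc(-c3ccccc3Cl)nn2)CC1` rests on a different core; the difference between the two cores is not broken down here. In this assay compound 3 gives 10 mg/kg, the lowest of the three numbers. Compound 4 `CNC(=O)OC1CCN(c2ccc(-c3ccc(Cl)cc3Cl)nn2)CC1` carries the change chloro in place of hydrogen on an aromatic carbon on compound 3. This is the same kind of change as that made from compound 1 to compound 2, though the place is not the same: here the chloro sits meta to a chloro group and para to a large group, whereas before it sat meta to a large group. Because the earlier step of a 1.9-fold lower number from compound 1 to compound 2 (0.28 log units; within the scatter) stayed within the scatter, a similarly small step is expected here, a 1.4-fold lower number from compound 3 to compound 4 (0.15 log units; within the scatter). Compound 4 is therefore expected to give about 7 mg/kg in this assay, most likely between 3 mg/kg and 16 mg/kg.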

Compound 4, dose for half-maximal effect: 5.5 mg/kg
Compound 4: the middle estimate sits 1.3-fold (0.10 log units) above what was measured; the measured number falls inside the stated range.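

In this assay, the added chloro gives a 1.8-fold lower number from compound 3 to compound 4 (0.26 log units; within the scatter), and set beside the earlier step it agrees in size: the same change on two cores in this assay, a 1.9-fold lower number (0.28 log units; within the scatter) from compound 1 to compound 2 and a 1.8-fold lower number (0.26 log units; within the scatter) from compound 3 to compound 4, 1.1-fold (0.02 log units) apart, within the scatter of two such steps

In this series, then, the change carried over between these two cores with a step of like size, even though the chloro stands in a different place in each pair. Each step stays within the scatter, however, and neither shows on its own that the chloro alters the dose at all; two pairs also say nothing about other cores.

The compounds shown leave open whether another group in the same place, such as methoxy or an amine, would give a step beyond the scatter.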